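The compounds below may be only part of what the source reports. "The series", "measured", "known", "first", "only" and "open" are said of these compounds alone.

Measured in a functional assay on NUGC-3 cells (Homo sapiens) for cytotoxicity, read by sulforhodamine B assay, with a stated time of 72 h; a lower number here means a stronger inhibitor of growth, a higher number a weaker inhibitor of growth:
- Compound 1 `CCCC(=O)N1c2ccccc2CCC1C(=O)Nc1ccccc1C(F)(F)F`: > 70000 nM, a limit of the assay
- Compound 2 `O=C(Nc1ccccc1C(F)(F)F)C1CCc2ccccc2N1`: 39300 nM
- Compound 3 `CCC(=O)N1c2ccccc2CCC1C(=O)Nc1ccccc1C(F)(F)F`: > 80000 nM, a limit of the assay

Compound 3 stands at a limit, not a number: > 80000 nM. Compound 4 `O=C(Nc1ccccc1C(F)(F)F)C1CCc2ccccc2N1C(=O)c1ccc(Cl)cc1` differs from it by 4-chlorophenyl in place of ethyl on a carbonyl carbon.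

Among the measured compounds shown here, two measured steps bear on this group: an at least 2.0-fold higher number from compound 2 to compound 3 (0.30 log units; that floor lies within the scatter) and an at least 1.7-fold lower number from compound 1 to compound 2 (0.25 log units; that floor lies within the scatter). A third, a step that the two limits leave unreadable from compound 1 to compound 3, gives no size. None of these steps brings in an aromatic ring, so the guide is weak. For the measured compounds named here, the only true number, compound 2 at 39300 nM, anchors the expectation of a modest move to a lower number in this assay. The expected step is an at least 2.0-fold lower number from compound 3 to compound 4 (0.30 log units; that floor lies within the scatter). For compound 4 the estimated value is 40000 nM, with an expected range from 8000 nM to 100000 nM.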

Compound 4, concentration for 50% growth inhibition: 551 nM
For compound 4 the middle estimate is 73-fold (1.86 log units) above the measured one; the whole stated range lies above it.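

Within this assay this position, a carbonyl carbon on the amide-type nitrogen in a ring, responds strongly to an aromatic ring: 4-chlorophenyl in place of ethyl gives an at least 140-fold lower number from compound 3 to compound 4 (2.16 log units; beyond the scatter) and 4-chlorophenyl in place of propyl gives an at least 120-fold lower number from compound 1 to compound 4 (2.10 log units; beyond the scatter) as its result. Compounds 1 and 3 each stand at a limit of the assay, so those two steps are floors. Among the compounds shown here, the one step between true numbers is a 71-fold lower number from compound 2 to compound 4 (1.85 log units; beyond the scatter) and shows that (4-chlorophenyl)carbonyl on this nitrogen brings a large drop.

From the compounds shown here alone, whether the chlorine or the ring itself matters stays open, and a plain phenyl or a pyridine ring on the same carbonyl would separate the two. The values shown give no measured reason for the drop.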